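Ethyl in Place of Methyl: Expectation for Compound 4

The source may hold more compounds than are shown below. What is called first, only, known or untested is meant among the compounds shown, and "the series" means these compounds.

Compound 1 `Cc1nc(N)c2nc(O)n(Cc3ccccc3)c2n1` sits second highest of the three numbers in a functional assay (spleen, spleen) for activation, with Mus musculus as the target (a higher number here means that more compound is needed for the effect, a lower number that less compound is needed), where compound 1 gives 1 uM. Compound 2 `CCCCc1nc(N)c2nc(O)n(Cc3ccccc3)c2n1` gives 0.03 uM in this assay, and compound 3 `Nc1ncnc2c1nc(O)n2Cc1ccccc1` gives 10 uM. The steps between them all point the same way: a 33-fold lower number from compound 1 to compound 2 (1.52 log units; beyond the scatter), with propyl in place of hydrogen on a saturated chain carbon bound to an aromatic carbon; a 10-fold higher number from compound 1 to compound 3 (1.00 log units; beyond the scatter), with hydrogen in place of methyl on an aromatic carbon; and a 330-fold higher number from compound 2 to compound 3 (2.52 log units; beyond the scatter). Within this small set the longer chain on the core carries the lower number, and none of the three compounds goes against this.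

Compound 4 `CCc1nc(N)c2nc(O)n(Cc3ccccc3)c2n1` differs from compound 1 by methyl in place of hydrogen on a saturated chain carbon bound to an aromatic carbon. The same difference, cut one bond further out, reads methyl to ethyl, so compound 4 stands between compound 1 and compound 2 in chain length. For the measured compounds named here, the steps that bear on it are those from compound 1 to compound 3 and from compound 1 to compound 2, both beyond the scatter. A downward step beyond the scatter is therefore expected from compound 1 to compound 4, smaller than the step to compound 2: a 5.0-fold lower number from compound 1 to compound 4 (0.70 log units; beyond the scatter). Compound 4 is estimated at 0.2 uM in this assay, expected to fall between 0.05 uM and 0.6 uM.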

Compound 4, minimum effective concentration: 1 uM
Estimate against measurement, compound 4: 5.0-fold (0.70 log units) below; measured number above the stated range.
By their numbers in this assay, from the lowest: compound 2; then compounds 1 and 4 (each within the scatter of the next); then compound 3.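

Notes on the chain on the saturated carbon bound to an aromatic carbon: in this assay, methyl in place of hydrogen at this place gives the step (no change at the digits printed from compound 1 to compound 4 (within the scatter)), so the change from methyl to ethyl leaves the number where it was. The earlier compounds shown here carried only methyl and butyl at this end of the series and could not show that the gain is absent at this first extension. Ethyl keeps the same separation from the compound with hydrogen on the aromatic carbon (a 10-fold lower number from compound 3 to compound 4 (1.00 log units; beyond the scatter)), and the whole gap to butyl remains (a 33-fold higher number from compound 2 to compound 4 (1.52 log units; beyond the scatter)), so within these four compounds the lower number appears only with butyl, and compound 4 goes against any steady fall with each added carbon. No supporting data bear on why ethyl and methyl read alike.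

Propyl would show whether the number falls at the next extension or only with butyl. Going by these compounds, whether pentyl or hexyl takes the number lower still, and how a terminal amine or carboxylic acid on the butyl chain would read, stays open.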